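This account rests on a few compounds, and the source may have more. Where it says the series, first, only, none or still open, it means among the compounds named here.

Compound 1 `COc1ccc(-c2cc(/C=C/C(=O)c3ccc(N)cc3)[nH]n2)cc1` and compound 2 `COc1cc(-c2cc(/C=C/C(=O)c3ccc(N)cc3)[nH]n2)cc(OC)c1OC` share one core and differ only in the methoxy pattern on one ring. In a functional assay on SW-620 cells (Homo sapiens) for cytotoxicity, read by sulforhodamine B assay, with a stated time of 48 h, tested at 1 uM (a higher number here means a weaker effect of the compound at the concentration tested, a lower number a stronger effect), compound 1 gives 72%, and compound 2 gives 82%. Compound 2 thus stands highest of the two numbers, yet its gap to compound 1 lies within the scatter, so no order can be read between them. Compound 3 `COc1ccc(-c2cc(/C=C/C(=O)c3ccc(N)cc3)[nH]n2)cc1OC` differs from compound 2 by hydrogen in place of methoxy on an aromatic carbon. No measured step of this kind is available among these compounds. The step of a number 5 percentage points lower from compound 2 to compound 3 (within the scatter) is expected to stay within the scatter, in no set direction. In this assay compound 3 is estimated at 77%, with a range from 64% to 90%.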

Compound 3, a percentage reported as activity, at one concentration (the size of the read-out at that concentration, not a potency): 95%
The estimate for compound 3 lay 18 percentage points below the measured number; the whole stated range lies below it.
By their numbers in this assay, from the lowest: compounds 1 and 2 (each within the scatter of the next); then compound 3.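

In this assay the methoxy count on this ring does not move the number in one direction: a number 13 percentage points higher from compound 2 to compound 3 (beyond the scatter), with hydrogen in place of methoxy, and a number 23 percentage points higher from compound 1 to compound 3 (beyond the scatter), with methoxy in place of hydrogen. Both single changes thus lead to compound 3, which has the weakest effect of the three, so the effect of a methoxy group here depends on the others on the ring. Nothing shown explains this turn. Going by these compounds, it remains open whether a hydroxyl or a chlorine on this aromatic carbon would behave like methoxy or like hydrogen.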